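A few compounds are considered here, and "the series" means these few. Any claim that something is new, unique, unknown or untested is made for them only; others in the source may bear on it.

Working notes on the series. Compound 3 `O=C(NCc1ccccc1)c1c(O)c2cccnc2n(-c2ccccc2)c1=O` holds the lowest of the three numbers in a functional assay on the whole organism for inhibition, with Rattus norvegicus as the target, read by cytopathic effect and paw edema, at a dose of 100 mg/kg by the oral route (a lower number here means less inhibition, a higher number more inhibition at the dose given (going by the name of the read-out)), giving 11.3%, though both other compounds sit within the scatter of it. Compound 1 `CNC(=O)c1c(O)c2cccnc2n(-c2ccccc2)c1=O` gives 21% in this assay, and compound 2 `CCCCNC(=O)c1c(O)c2cccnc2n(-c2ccccc2)c1=O` gives 20.4%. All three measured steps change the group on a saturated chain carbon bound to an amide-type nitrogen: a number 0.6 percentage points lower from compound 1 to compound 2 (within the scatter), a number 9.7 percentage points lower from compound 1 to compound 3 (within the scatter) and a number 9.1 percentage points lower from compound 2 to compound 3 (within the scatter); none reached beyond the scatter. Compound 4 `CN(C)CCNC(=O)c1c(O)c2cccnc2n(-c2ccccc2)c1=O` is the next member and is not yet measured. It differs from compound 3 at the same place: (dimethylamino)methyl in place of phenyl on a saturated chain carbon bound to an amide-type nitrogen. Within the data shown here, the entering group has no counterpart among the measured compounds, so the three steps bear on the step to compound 4 only by showing that hydrogen, propyl and phenyl at this position all gave numbers within the scatter of one another. No step beyond the scatter is therefore expected in this assay, the expected step being a number 3.7 percentage points higher from compound 3 to compound 4 (within the scatter). Compound 4 is estimated at 15% in this assay, with a range from 4% to 30% within which four of five repeat measurements should fall.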

Compound 4, a percentage reported as inhibition, in the whole organism at one dose (the size of the read-out at that dose, not a potency): 18.4%
For compound 4 the middle estimate is 3.4 percentage points below the measured one; the range from low to high includes it.
By their numbers in this assay, from the lowest: compounds 3, 4, 2 and 1 (each within the scatter of the next).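

In this assay, among these compounds, (dimethylamino)methyl is the first entering group at this place on a saturated chain carbon bound to an amide-type nitrogen that holds a nitrogen atom and a hydrogen-bond acceptor, and all three of its steps lie within the scatter (a number 7.1 percentage points higher from compound 3 to compound 4 (within the scatter); a number 2 percentage points lower from compound 2 to compound 4 (within the scatter); a number 2.6 percentage points lower from compound 1 to compound 4 (within the scatter)). The range of groups that leaves the number within the scatter therefore widens: hydrogen, propyl and phenyl gave no step beyond it, and neither does this acyclic amine-bearing group, including where it replaces the six-membered aromatic ring of compound 3 or, counted two bonds along the chain, where dimethylamino replaces the ethyl of compound 2. No measurement bears on why these groups give numbers within the scatter of one another, and no cause can be offered for this result.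

The compounds shown leave open whether any group at this place can produce a step beyond the scatter, for instance a carboxylic acid, a morpholine ring or a longer chain carrying the dimethylamino group. They also leave open whether these four compounds would still lie within the scatter of one another in this assay at a dose other than the single one given.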